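This account rests on a few compounds, and the source may have more. Where it says the series, first, only, none or still open, it means among the compounds named here.

Measured so far:
- compound 1, `O=C(Nc1cccc(-c2ccoc2)c1)C(Cl)Cl`: 8480 nM
- compound 2, `COc1cccc(-c2cc(NC(=O)C(Cl)Cl)cc(-c3cccc(OC)c3)c2)c1`: 9400 nM
- compound 3, `COc1ccc(-c2cc(NC(=O)C(Cl)Cl)cc(-c3ccc(OC)c(F)c3)c2)cc1F`: 1950 nM

All three numbers come from a functional assay on A549 cells (Homo sapiens) for cytotoxicity, read by MTT assay, with a stated time of 68 h; on this read-out lower numbers stand for stronger inhibition and higher numbers for weaker inhibition. On these numbers compound 1 stands second highest of three. Its nearest neighbour is compound 2, whose value of 9400 nM lies within the scatter of compound 1, so the two cannot be told apart here. Compound 3, at 1950 nM, sits furthest from compound 1, and that gap is beyond the scatter; compound 3 is the one of the three with the lowest number.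

Compound 4, `O=C(Nc1cccc(-c2cccs2)c1)C(Cl)Cl`, differs from compound 1 in a single place: thiophen-2-yl in place of furan-3-yl on an aromatic carbon. Among the compounds with values here, no pair among the measured compounds shows this kind of exchange, so nothing in the set calibrates it. Both groups are five-membered aromatic rings with one hetero atom and one hydrogen-bond acceptor, and the change is small in count. The expectation for this assay is therefore a step no larger than the scatter, in no fixed direction, with compound 4 estimated to stay close to compound 1 and the expected step being a 1.1-fold lower number from compound 1 to compound 4 (0.05 log units; within the scatter). Compound 4 is thus estimated at 7500 nM, with a range from 2500 nM to 22000 nM.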

Compound 4, half-maximal inhibitory concentration: 47600 nM
Beside the measured number, compound 4's estimate is 6.3-fold (0.80 log units) below it, and the stated range ends below it.
By their numbers in this assay, from the lowest: compound 3; then compounds 1 and 2 (each within the scatter of the next); then compound 4.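

In this assay, thiophen-2-yl in place of furan-3-yl on this aromatic carbon gives a 5.6-fold higher number from compound 1 to compound 4 (0.75 log units; beyond the scatter), so this position does not treat the two rings as interchangeable, even though their counts of heavy atoms and hydrogen-bond acceptors match. The exchange alters both the ring hetero atom and the point of attachment, and this single step cannot separate the two changes. No measurement bearing on the origin of the step is available.

Open, from the compounds shown here alone, is how furan-2-yl or thiophen-3-yl would read at the same place, since either would pull apart the hetero atom and the point of attachment. Also open, going by these compounds, is whether a six-membered pyridin-3-yl ring or a simple amine on this carbon would stay near compound 1 or compound 4.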